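Methoxy to formyl on the terminal phenyl ring

A few compounds are considered here, and "the series" means these few. Any claim that something is new, unique, unknown or untested is made for them only; others in the source may bear on it.

Measured compounds in a functional assay on EKVX cells (Homo sapiens) for inhibition, read by sulforhodamine B assay, with a stated time of 48 h, tested at 10 uM; a higher number here means more inhibition at the concentration tested (going by the name of the read-out), a lower number less inhibition:
- compound 1 `Brc1cn2ccnc2c(-c2ccc3ncn(C4CCCCC4)c3c2)n1`: compound 1 gives 12%
- compound 2 `c1ccc(-c2cn3ccnc3c(-c3ccc4ncn(C5CCCCC5)c4c3)n2)cc1`: compound 2 gives 24.2%
- compound 3 `COc1ccc(-c2cn3ccnc3c(-c3ccc4ncn(C5CCCCC5)c4c3)n2)cc1`: compound 3 gives 56.7%

Compound 3 holds the highest number of the three. Its margin over compound 2 is a number 32.5 percentage points higher from compound 2 to compound 3 (beyond the scatter), and over compound 1 it is a number 44.7 percentage points higher from compound 1 to compound 3 (beyond the scatter), both beyond the scatter. The step from bromo to phenyl, a number 12.2 percentage points higher from compound 1 to compound 2 (beyond the scatter), is the smallest step in the set.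

Compound 4 `O=Cc1ccc(-c2cn3ccnc3c(-c3ccc4ncn(C5CCCCC5)c4c3)n2)cc1` differs from compound 3 by formyl in place of methoxy on an aromatic carbon. For the measured compounds named here, no measured step swaps one substituent for another on this phenyl ring; the only step touching that position, a number 32.5 percentage points higher from compound 2 to compound 3 (beyond the scatter), shows that adding methoxy there raised the number strongly, so removing it is the relevant reference. Whether formyl recovers any of that gain cannot be read from the measured compounds. Compound 4 is therefore expected to show a step downward in this assay of roughly a number 24.7 percentage points lower from compound 3 to compound 4 (beyond the scatter), which would land it near compound 2. Compound 4 is estimated at 32%, with a range from 10% to 58%.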

Compound 4, a percentage reported as inhibition, at one concentration (the size of the read-out at that concentration, not a potency): 20.9%
Estimate against measurement, compound 4: 11.1 percentage points above; the measured number falls inside the stated range.
By their numbers in this assay, from the lowest: compounds 1, 4 and 2 (each within the scatter of the next, the first and the last beyond it); then compound 3.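

In this assay, the rise that methoxy brought to the terminal phenyl ring is specific enough that formyl does not keep it, with a number 35.8 percentage points lower from compound 3 to compound 4 (beyond the scatter) for a swap between two small groups on the same aromatic carbon. Formyl in place of hydrogen gives a number 3.3 percentage points lower from compound 2 to compound 4 (within the scatter), and 4-formylphenyl in place of bromo gives a number 8.9 percentage points higher from compound 1 to compound 4 (within the scatter), so neither step separates compound 4 from the compound it is compared with. Among the groups shown at this place, only methoxy stands apart, and nothing available here bears on the reason for this.

As far as these compounds go, whether an ethoxy group, a hydroxyl or an amine at this place would match methoxy remains open. So does the outcome for a carboxylic acid or a nitrile there.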